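The compounds below may be only part of what the source reports. "The series", "measured", "known", "first", "only" and "open" are said of these compounds alone.

Measured in a functional assay on A549 cells (Homo sapiens) for inhibition, read by CCK-8 assay, with a stated time of 72 h, tested at 1 uM; a lower number here means less inhibition of growth, a higher number more inhibition of growth at the concentration tested:
- Compound 1 `CN(C)C(=O)c1cc2cnc(Nc3ccc(NC(=O)C4(C(=O)Nc5ccc(F)cc5)CC4)cc3)nc2n1C1CCCC1`: 86.6%
- Compound 2 `CN(C)C(=O)c1cc2cnc(Nc3ccc(NC(=O)C4(C(=O)Nc5ccc(Br)cc5)CC4)cc3)nc2n1C1CCCC1`: -6.6%
- Compound 3 `CN(C)C(=O)c1cc2cnc(Nc3ccc(NC(=O)C4(C(=O)Nc5cccc(C#N)c5)CC4)cc3)nc2n1C1CCCC1`: 70.8%

Compound 3 stands second highest of the three, below compound 1 and above compound 2. The next candidate is compound 4 `CN(C)C(=O)c1cc2cnc(Nc3ccc(NC(=O)C4(C(=O)Nc5ccccc5)CC4)cc3)nc2n1C1CCCC1`, which has not yet been measured in this assay. Its structure departs from compound 3 by one change, hydrogen in place of cyano on an aromatic carbon, which turns the 3-cyanophenyl into a phenyl.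

Among the compounds with values here, no measured step removes a substituent from this ring outright, so the evidence is indirect. Within the data shown here, three steps bear on the change, all of them swaps on the same ring. The step of a number 15.8 percentage points lower from compound 1 to compound 3 (beyond the scatter) is modest, while a number 93.2 percentage points lower from compound 1 to compound 2 (beyond the scatter) and a number 77.4 percentage points higher from compound 2 to compound 3 (beyond the scatter) are large, and both large steps involve the bromo compound 2. These three compounds alone cannot show whether compound 2 is an exception, so a sharp fall for compound 4 cannot be ruled out. Compound 1 and compound 3 nevertheless both hold high values, and a similar level seems likeliest.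

The expected result is a number 0.8 percentage points lower from compound 3 to compound 4 (within the scatter), so no clear shift in either direction is anticipated. For compound 4 the estimated value is 70%, with an expected range from 38% to 92%.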

Compound 4, percent growth inhibition at one concentration: 75%
The estimate for compound 4 lay 5 percentage points below the measured number; measured number inside the range.
By their numbers in this assay, from the lowest: compound 2; then compounds 3 and 4 (each within the scatter of the next); then compound 1.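

In this assay, within the data shown here, the bare phenyl ring gives the first reading with no substituent on this ring, and taking away the cyano gives a number 4.2 percentage points higher from compound 3 to compound 4 (within the scatter) so a nitrile at this place is not needed to hold a high number. Against the same bare ring, bromo stands out as the one substituent among these that goes with a collapse, at a number 81.6 percentage points higher from compound 2 to compound 4 (beyond the scatter) while fluoro keeps only a modest edge over hydrogen, with a number 11.6 percentage points lower from compound 1 to compound 4 (beyond the scatter) and so the large steps seen earlier now read as a feature of the bromo compound rather than of substitution on this ring in general. No measurement shown accounts for the loss with bromo or the edge with fluoro.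

On these data alone, whether the fall belongs to bromo alone or would also appear with a chloro or a methoxy group on this ring stays open. So does how an amine or a carboxylic acid on this ring would compare with the bare phenyl of compound 4 at this single concentration.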